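The compounds below may be only part of what the source reports. "The series", "measured", "known", "first", "only" and "open" are said of these compounds alone.

Working notes on the series. Compound 1 `O=C(CCCCCCc1ccccc1)CC(=O)N[C@H]1CCOC1=O`, compound 2 `O=C(CCCCCCCCc1ccccc1)CC(=O)N[C@H]1CCOC1=O` and compound 3 `O=C(CCCCCCCc1ccccc1)CC(=O)N[C@H]1CCOC1=O` share one core. In a functional assay on NCI-H630 cells (Homo sapiens) for cytotoxicity, read by sulforhodamine B assay, with a stated time of 5 days (a higher number here means a weaker inhibitor, a lower number a stronger inhibitor), compound 1 gives 65000 nM, compound 3 gives 42000 nM and compound 2 gives 11000 nM. Compound 2 holds the lowest number of the three: a 5.9-fold lower number from compound 1 to compound 2 (0.77 log units; beyond the scatter) and a 3.8-fold higher number from compound 2 to compound 3 (0.58 log units; beyond the scatter) are both beyond the scatter, while a 1.5-fold lower number from compound 1 to compound 3 (0.19 log units; within the scatter) stays within it. Compound 4 `O=C(CCCCCCCCCCCc1ccccc1)CC(=O)N[C@H]1CCOC1=O` carries 3-phenylpropyl in place of phenyl on a saturated chain carbon, eight bonds along the chain from a carbonyl carbon. Among the measured compounds shown here, the steps that bear on this are a 5.9-fold lower number from compound 1 to compound 2 (0.77 log units; beyond the scatter) and a 3.8-fold higher number from compound 2 to compound 3 (0.58 log units; beyond the scatter), each a modest step toward lower numbers as the chain grows; a further modest lowering is therefore expected, a 2.8-fold lower number from compound 2 to compound 4 (0.44 log units; beyond the scatter), though no measured point past compound 2 fixes its size. Compound 4 is estimated at 4000 nM, range 1500 nM to 12000 nM.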

Compound 4, half-maximal inhibitory concentration: 33000 nM
Compound 4: the middle estimate sits 8.3-fold (0.92 log units) below what was measured, and the stated range ends below it.
By their numbers in this assay, from the lowest: compound 2; then compounds 4, 3 and 1 (each within the scatter of the next).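

At this position, on a saturated chain carbon, eight bonds along the chain from a carbonyl carbon, 3-phenylpropyl in place of phenyl gives a 3.0-fold higher number from compound 2 to compound 4 (0.48 log units; beyond the scatter) in this assay and so reverses the lowering seen up to compound 2. Lengthening the chain therefore does not keep lowering the number, and compound 2 now sits lowest with compound 1 and compound 3 on its shorter side and compound 4 on its longer side. Nothing available accounts for this reversal.

On these data alone, whether a still longer chain would raise the number further stays open. So does the outcome of replacing the terminal phenyl with an amine or a carboxylic acid.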